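The compounds below may be only part of what the source reports. "The series", "measured", "known", "first", "only" and "open" are said of these compounds alone.

Measured in a physicochemical assay for solubility, with a stated time of 18 h, at pH 7.4; a higher number here means a more soluble compound, a lower number a less soluble compound:
- Compound 1 `FC(F)(F)c1ccc(-c2ccc3c(NCCCNCc4ccco4)ccnc3c2)cc1`: 32000 nM
- Compound 2 `c1ccc(CCc2ccc3c(NCCCNCc4ccco4)ccnc3c2)cc1`: 4200 nM
- Compound 3 `Fc1ccc(Oc2ccc3c(NCCCNCc4ccco4)ccnc3c2)cc1`: 14500 nM

Compound 3 holds the middle of these three values, as shown by a 2.2-fold lower number from compound 1 to compound 3 (0.34 log units; beyond the scatter) and by a 3.5-fold higher number from compound 2 to compound 3 (0.54 log units; beyond the scatter). The unmeasured compound 4 `CCC(CC)c1ccc2c(NCCCNCc3ccco3)ccnc2c1` keeps the shared core and alters one group, with pentan-3-yl in place of 4-fluorophenoxy on an aromatic carbon.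

All three measured steps involve a swap on an aromatic carbon, and all are modest but beyond the scatter. The largest is a 7.6-fold lower number from compound 1 to compound 2 (0.88 log units; beyond the scatter). Each of the three groups measured so far carries a ring, whereas pentan-3-yl has none, so these steps suggest a likely size but no firm direction. A step no larger than these is expected in this assay, leaning slightly upward, and it may stay within the scatter.

The expected change is a 1.4-fold higher number from compound 3 to compound 4 (0.14 log units; within the scatter). For compound 4 the estimated value is 20000 nM, with an expected range of 7000 nM to 60000 nM.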

Compound 4, solubility: 4200 nM
Compound 4: the middle estimate sits 4.8-fold (0.68 log units) above what was measured; measured number below the stated range.
By their numbers in this assay, from the lowest: compounds 2 and 4 (each within the scatter of the next); then compound 3; then compound 1.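

In this assay, within the data shown here, pentan-3-yl is the first group at this aromatic carbon that has no ring, and it gives a lower number than two of the ring-bearing groups: a 3.5-fold lower number from compound 3 to compound 4 (0.54 log units; beyond the scatter), and a 7.6-fold lower number from compound 1 to compound 4 (0.88 log units; beyond the scatter). Against phenethyl, however, the swap gives no change at the digits printed from compound 2 to compound 4 (within the scatter), so at this position a group with no ring and a group carrying a ring can give the same reading, and the presence of a ring alone does not set the number. The compounds offer no separate measurement that accounts for these steps.

Going by these compounds, it remains open how an amine, a carboxylic acid or a longer chain at this position would compare with pentan-3-yl. Also open, on these data alone, is whether these steps would hold with another part of the shared core changed.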